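The source may hold more compounds than are shown below. What is called first, only, known or untested is meant among the compounds shown, and "the series" means these compounds.

Compound 1 `CO[C@H]1O[C@H](COc2cccc3c2CCCC3)[C@@H](O)[C@H](O)[C@H]1Oc1ccc(OC2CCCCC2)cc1`: in a functional assay on MDA-MB-231 cells (Homo sapiens) for cytotoxicity, read by MTT assay, with a stated time of 48 h, tested at 20 uM (on this read-out lower numbers stand for less inhibition and higher numbers for more inhibition at the one concentration tested (going by the name of the read-out)), compound 1 gives -8%.
Compound 2 `CO[C@H]1O[C@H](COc2ccc3c(c2)CCCC3)[C@@H](O)[C@H](O)[C@H]1Oc1ccc(OC2CCCCC2)cc1`: in this assay compound 2 gives 24%.
Compound 3 `CO[C@@H]1O[C@H](COc2ccc3c(c2)CCCC3)[C@@H](O)[C@H](O)[C@H]1Oc1ccc(OC2CCCCC2)cc1`: in this assay compound 3 gives 0%.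

Compound 3 is second highest of the three numbers: close to compound 1, within the scatter, and set apart from compound 2 by a number 24 percentage points lower from compound 2 to compound 3 (beyond the scatter), a pair for which (the fact that compounds 2 and 3 differ only in the configuration as drawn). Compound 4 `CO[C@@H]1O[C@H](COc2ccc(-c3ccccc3)cc2)[C@@H](O)[C@H](O)[C@H]1Oc1ccc(OC2CCCCC2)cc1` differs from compound 3 by 4-phenylphenyl in place of 1,2,3,4-tetrahydronaphthalen-6-yl on an oxygen on a saturated carbon. Among the measured compounds shown here, no measured step swaps this aryl group in the same way; the nearest is a number 32 percentage points higher from compound 1 to compound 2 (beyond the scatter), which shows that a change in the aryl on this oxygen can shift the read-out a long way. The configurational step is a different kind of change and gives no direction. A modest step is expected, direction uncertain, leaning upward: a number 8 percentage points higher from compound 3 to compound 4 (within the scatter). Compound 4 is estimated at 8%, between -15% and 35%.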

Compound 4, a percentage reported as inhibition, at one concentration (the size of the read-out at that concentration, not a potency): 64%
Beside the measured number, compound 4's estimate is 56 percentage points below it; the measured number lies above the stated range.
By their numbers in this assay, from the lowest: compounds 1 and 3 (each within the scatter of the next); then compound 2; then compound 4.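

Replacing 1,2,3,4-tetrahydronaphthalen-6-yl with 4-phenylphenyl on this oxygen gives a number 64 percentage points higher from compound 3 to compound 4 (beyond the scatter) in this assay. The earlier aryl step only moved the attachment point on the tetrahydronaphthalene, whereas this one shows that changing the aryl group itself also shifts the read-out strongly. The configuration drawn in compound 3, the lower member of its stereo pair, therefore does not by itself keep the read-out low; nothing available explains the size of this step.

On these data alone, the effect of 4-phenylphenyl in the configuration of compound 2 remains open. So does the outcome with a naphthyl group or a 4-carboxyphenyl group on this oxygen.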